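Bromophenyl and fluorophenyl amines: from compound 3 to compound 4

The source may hold more compounds than are shown below. What is called first, only, known or untested is meant among the compounds shown, and "the series" means these compounds.

Values in a functional assay on MDA-MB-468 cells (Homo sapiens) for antiproliferative activity, read by MTT assay, with a stated time of 24 h; on this read-out higher numbers stand for weaker inhibition and lower numbers for stronger inhibition:
Compound 1 `CNC(=O)c1ccccc1Oc1nc(Nc2ccc(Br)cc2)ncc1Br` gives 36600 nM
Compound 2 `CNC(=O)c1ccccc1Oc1nc(Nc2ccc(C(F)(F)F)cc2)ncc1Br` gives > 50000 nM, a limit
Compound 3 `CNC(=O)c1ccccc1Oc1nc(Nc2ccccc2F)ncc1Br` gives > 50000 nM, a limit

Going by these compounds, compound 3 stands only at a limit, > 50000 nM, so its true value is unknown. With compound 2 it makes up (the limit of > 50000 nM in this assay, at which 2 of the 3 values shown sit). Compound 1 is the only one of the three with a number.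

The next compound is compound 4 `CNC(=O)c1ccccc1Oc1nc(Nc2cccc(Br)c2)ncc1Br`, and the change is 3-bromophenyl in place of 2-fluorophenyl on a nitrogen on an aromatic ring.

For the measured compounds named here, two measured steps bear on this. The closer one is an at least 1.3-fold higher number from compound 1 to compound 3 (0.13 log units; that floor lies within the scatter), which swaps 2-fluorophenyl for 4-bromophenyl at the same place. The other is an at least 1.3-fold higher number from compound 1 to compound 2 (0.13 log units; that floor lies within the scatter). Both give only floors, and both floors lie within the scatter, so neither fixes a size. Going by the values given here, no 3-bromophenyl compound has been measured. Compound 4 does keep a bromophenyl group, as compound 1 does with 36600 nM, so a small move toward lower numbers is expected in this assay, or none beyond the scatter. A reading at the limit remains about as likely as a number.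

The expected change is an at least 1.1-fold lower number from compound 3 to compound 4 (0.07 log units; that floor lies within the scatter).

For compound 4 the estimate is 42000 nM, with an expected range of 22000 nM to 80000 nM.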

Compound 4, half-maximal inhibitory concentration: 31900 nM
Compound 4: the middle estimate sits 1.3-fold (0.12 log units) above what was measured, within the range that was stated.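

In this assay, 3-bromophenyl in place of 4-bromophenyl on the nitrogen gives a 1.1-fold lower number from compound 1 to compound 4 (0.06 log units; within the scatter), so the two bromophenyl compounds cannot be told apart and this change has no readable effect. Compound 4 also gives a second number at this position, but the step from the 2-fluorophenyl compound is only a floor, an at least 1.5-fold lower number from compound 3 to compound 4 (0.19 log units; that floor lies within the scatter), and it fixes no size for the change. Compound 2 and compound 3 remain at a limit rather than a number, so among the compounds shown only the two bromophenyl groups give numbers, and no group can be ranked against them: the limit of > 50000 nM in this assay, at which 2 of the 4 values shown sit.

Going by these compounds, whether a number is kept with a chloro, methoxy or amino group on the phenyl ring stays open, and a carboxylic acid or a longer chain there would test the same question. The compounds shown also leave open how far the values depend on the rest of the shared core, since the methyl amide and the bromo group on the core stay the same throughout.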